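From 3-hydroxyphenyl to 4-(dimethylamino)phenyl on a shared core

The source may hold more compounds than are shown below. What is called first, only, known or untested is meant among the compounds shown, and "the series" means these compounds.

In a functional assay on A549 cells (Homo sapiens) for inhibition, read by MTT assay, with a stated time of 48 h (on this read-out lower numbers stand for stronger inhibition and higher numbers for weaker inhibition), compound 1 `c1ccc(C(c2c[nH]c3ccccc23)c2c[nH]c3ccccc23)cc1` gives 40000 nM, compound 2 `Oc1ccc(C(c2c[nH]c3ccc(Br)cc23)c2c[nH]c3ccc(Br)cc23)cc1` gives 9000 nM and compound 3 `Oc1cccc(C(c2c[nH]c3ccc(Br)cc23)c2c[nH]c3ccc(Br)cc23)c1` gives 8000 nM. Compound 3 therefore sits within the usual scatter of compound 2, and both numbers are lower than that of compound 1, meaning stronger inhibition.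

The next structure is compound 4 `CN(C)c1ccc(C(c2c[nH]c3ccc(Br)cc23)c2c[nH]c3ccc(Br)cc23)cc1`, where 4-(dimethylamino)phenyl takes the place of 3-hydroxyphenyl on a saturated chain carbon bound to two aromatic carbons: 4-(dimethylamino)phenyl in place of 3-hydroxyphenyl on a saturated chain carbon bound to two aromatic carbons.

Among the measured compounds shown here, only one measured step bears on this site. In a 1.1-fold lower number from compound 2 to compound 3 (0.05 log units; within the scatter), 3-hydroxyphenyl replaced 4-hydroxyphenyl, and the number stayed within the scatter. For the measured compounds named here, that step only relocates the hydroxy group, and no measured compound carries 4-(dimethylamino)phenyl, so the evidence is thin. With nothing pointing either way, no shift beyond the scatter is expected in this assay, and the expected change is no change at the digits printed from compound 3 to compound 4 (within the scatter).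

For compound 4, the estimated value is 8000 nM, with an expected range of 3000 nM to 22000 nM.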

Compound 4, half-maximal inhibitory concentration: 25000 nM
Compound 4: the middle estimate sits 3.1-fold (0.49 log units) below what was measured; the whole stated range lies below it.
By their numbers in this assay, from the lowest: compounds 3 and 2 (each within the scatter of the next); then compounds 4 and 1 (each within the scatter of the next).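

In this assay this position does respond to a change of group: moving the hydroxy group had left the number within the scatter, but 4-(dimethylamino)phenyl in place of 3-hydroxyphenyl gives a 3.1-fold higher number from compound 3 to compound 4 (0.49 log units; beyond the scatter), and dimethylamino in place of hydroxy gives a 2.8-fold higher number from compound 2 to compound 4 (0.44 log units; beyond the scatter). Both steps are modest but beyond the scatter, and both mean weaker inhibition, so the group on this ring matters more here than where the hydroxy group sits. Nothing shown explains why the number rises.

From the compounds shown here alone, it stays open whether the rise follows from losing the hydroxy group or from adding dimethylamino. A methoxy group or an unsubstituted amine on the same ring, with the rest of the shared core unchanged, would help to separate these two readings.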